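Swapping the aryl group on the amine: effect on cytotoxicity

The source may hold more compounds than are shown below. What is called first, only, known or untested is meant among the compounds shown, and "the series" means these compounds.

Measured compounds:
compound 1 `Cc1cc(-c2ccc(C#N)cc2)cc(C)c1Oc1nc(Nc2ccc(C#N)c(F)c2)nc2ccsc12`: 71500 nM
compound 2 `Cc1cc(-c2ccc(C#N)cc2)cc(C)c1Oc1nc(Nc2ccc(C#N)nc2)nc2ccsc12`: 214000 nM
compound 3 `N#C/C=C/c1cc(F)c(Oc2nc(Nc3ccc(C#N)c(F)c3)nc3cc[nH]c23)c(F)c1`: 10200 nM

In a toxicity assay on MT4 cells (Homo sapiens) for cytotoxicity, read by MTT assay, with a stated time of 5 days (a lower number here means that less compound is tolerated, a higher number that more compound is tolerated), these three compounds were tested, and compound 4 `N#C/C=C/c1cc(F)c(Oc2nc(Nc3ccc(C#N)nc3)nc3cc[nH]c23)c(F)c1` is still to be measured. Compound 1 and compound 2 share one core and differ only by 6-cyanopyridin-3-yl in place of 4-cyano-3-fluorophenyl on a nitrogen on an aromatic ring; this single change made a step of a 3.0-fold higher number from compound 1 to compound 2 (0.48 log units; beyond the scatter). Compound 3 carries a different core; the difference between the two cores is not broken down here. Compound 3 gives 10200 nM, the lowest of the three numbers. Among the measured compounds shown here, compound 4 is made from compound 3 by 6-cyanopyridin-3-yl in place of 4-cyano-3-fluorophenyl on a nitrogen on an aromatic ring, the same change as the one from compound 1 to compound 2, at the same place. For the measured compounds named here, with only one earlier example, the step is expected to be about a 2.5-fold higher number from compound 3 to compound 4 (0.39 log units; beyond the scatter), resting on the earlier step of a 3.0-fold higher number from compound 1 to compound 2 (0.48 log units; beyond the scatter). The estimate for compound 4 in this assay is therefore 25000 nM, with a plausible range from 8000 nM to 70000 nM.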

Compound 4, half-maximal cytotoxic concentration: 29000 nM
Compound 4: middle estimate off by 1.2-fold (0.06 log units), on the low side, and the stated range covers the measured number.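

In this assay, putting 6-cyanopyridin-3-yl in place of 4-cyano-3-fluorophenyl on a nitrogen on an aromatic ring gives a 2.8-fold higher number from compound 3 to compound 4 (0.45 log units; beyond the scatter), so the cells tolerate more of the compound after the swap. Set beside the earlier case, the step keeps its size when carried from one core to the other: the same change on two cores in this assay, a 3.0-fold higher number (0.48 log units; beyond the scatter) from compound 1 to compound 2 and a 2.8-fold higher number (0.45 log units; beyond the scatter) from compound 3 to compound 4, 1.1-fold (0.02 log units) apart, within the scatter of two such steps. On these two cores and in this one assay, the change therefore behaves as a transferable step, but two pairs are a small sample, and they show neither why the number moves nor whether the same holds on other cores or in other assays.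

The compounds shown leave open whether another group on that nitrogen, such as a phenyl ring carrying a carboxylic acid or an amine in place of the nitrile, would shift the number equally on both cores. Compound 1 and compound 3 also differ in more than one place, so the effect of the core itself cannot be read from them.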